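The source may hold more compounds than are shown below. What is called first, only, known or untested is meant among the compounds shown, and "the series" means these compounds.

Measured compounds in this study:
- compound 1, `COc1cc(OC)c(Cl)c(-c2ccc3c(NC(=O)c4ccc(C5CCN(C)CC5)cc4)n[nH]c3n2)c1Cl`: 8.2 nM
- compound 2, `COc1cc(OC)c(Cl)c(-c2ccc3c(NC(=O)c4ccc(N5CCN(C)CC5)c(Cl)c4)n[nH]c3n2)c1Cl`: 191 nM
- compound 3, `COc1cc(N2CCN(C)CC2)ccc1C(=O)Nc1n[nH]c2nc(-c3c(Cl)c(OC)cc(OC)c3Cl)ccc12`: 525 nM

The three compounds share a core, each carrying an amide whose aryl part differs. In a functional assay on NCI-H1581 cells (Homo sapiens) for antiproliferative activity, read by CCK-8 assay, with a stated time of 72 h (on this read-out lower numbers stand for stronger inhibition and higher numbers for weaker inhibition), compound 1 gives 8.2 nM, the lowest of the three numbers. In this assay compound 2 gives 191 nM and compound 3 gives 525 nM; both of these lie beyond the usual scatter from compound 1. Going by the values given here, no pair of measured compounds differs in only one place, so no single clean step can be drawn between them, and the gaps from compound 1 to compound 2 and compound 3 show only that those two aryl groups, taken as wholes, go with weaker inhibition.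

Compound 4, `COc1cc(OC)c(Cl)c(-c2ccc3c(NC(=O)c4ccccc4)n[nH]c3n2)c1Cl`, differs from compound 1 in one place: hydrogen in place of 1-methylpiperidin-4-yl on an aromatic carbon. The group that leaves sits on an aromatic carbon of a six-membered aromatic ring of carbon only, para to a large group.

Among the compounds with values here, nothing among the measured compounds isolates this change. The weaker results of compound 2 and compound 3, which carry different groups in that region while also differing elsewhere, give only a loose hint. For compound 4 a moderate step towards weaker inhibition in this assay is expected, namely a 4.3-fold higher number from compound 1 to compound 4 (0.63 log units; beyond the scatter), with wide uncertainty. Compound 4 is estimated at 35 nM, within a range from 6 nM to 250 nM.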

Compound 4, half-maximal inhibitory concentration: > 1000 nM
Compound 4: only a limit was reported; the forecaster's own chance of this, stated with the estimate: 5%; middle value at least 28-fold (1.45 log units) away from the limit.
By their numbers in this assay, from the lowest: compound 1; then compound 2; then compound 3. At a limit, above all of these: compound 4.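

In this assay compound 4 reaches only a limit, > 1000 nM, which is a boundary of the assay and not a number. Going by these compounds alone, replacing the 1-methylpiperidin-4-yl group with hydrogen on this aromatic carbon gives an at least 120-fold higher number from compound 1 to compound 4 (2.08 log units; beyond the scatter), a large step and the first comparison in this set that changes only one place, showing that inhibition in this assay depends heavily on what sits here and that the bare aromatic ring does not retain the result of compound 1. The full size of the step cannot be read from this result, since the value for compound 4 stops here: the limit of > 1000 nM in this assay, at which 1 of the 4 values shown sits.

The compounds shown leave open which part of the 1-methylpiperidin-4-yl group matters: whether a piperidin-4-yl group with hydrogen in place of the methyl, or a cyclohexyl ring with no nitrogen at all, would stay close to compound 1 at 8.2 nM. They also leave open whether a much smaller group on the same carbon, such as a dimethylamino group, would recover any of the lost inhibition.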